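Replacing the bicyclic group in compound 3 by ethoxymethyl

The source may hold more compounds than are shown below. What is called first, only, known or untested is meant among the compounds shown, and "the series" means these compounds.

Compound 3 `COc1ncccc1C(=O)NCCC1CCN(S(=O)(=O)NC(=O)NC[C@@H]2C[C@@H]3CC[C@@H]2C3)CC1` stands highest of the three numbers on a functional assay on the whole organism (blood) with Rattus norvegicus as the target, with stated times of 24 h and 1 h, at a dose of 5 mg/kg by the intraperitoneal route; on this read-out lower numbers stand for a weaker effect and higher numbers for a stronger effect at the one dose given: compound 3 gives 35%, compound 2 `COc1ncccc1C(=O)NCCC1CCN(S(=O)(=O)NC(=O)NC[C@H]2C[C@@H]3C=C[C@@H]2C3)CC1` gives 20% and compound 1 `CC(=O)NCCC1CCN(S(=O)(=O)NC(=O)NC[C@@H]2C[C@@H]3C=C[C@@H]2C3)CC1` gives 18%. Going by the values given here, the one measured step at the same place, a number 15 percentage points higher from compound 2 to compound 3 (beyond the scatter), exchanges one bicyclic group for another and is the only guide for this position. Compound 4 `CCOCCNC(=O)NS(=O)(=O)N1CCC(CCNC(=O)c2cccnc2OC)CC1` differs from compound 3 by a group of 4 heavy atoms (3 carbon, 1 oxygen; no ring) in place of a group of 7 heavy atoms (7 carbon; 2 five-membered non-aromatic rings of carbon only), on a saturated chain carbon bound to an amide-type nitrogen. Among the compounds with values here, no measured step exchanges a ring group there for an open chain, so the direction is uncertain. A step beyond the scatter is nevertheless expected for compound 4, most plausibly downward, since a change at this place moved the read-out in a number 15 percentage points higher from compound 2 to compound 3 (beyond the scatter); the expected step is a number 13 percentage points lower from compound 3 to compound 4 (beyond the scatter). Compound 4 is estimated at 22%, between 8% and 38%.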

Compound 4, a percentage reported as activity, at one dose (the size of the read-out at that dose, not a potency): 7%
The estimate for compound 4 lay 15 percentage points above the measured number; the whole stated range lies above it.
By their numbers in this assay, from the lowest: compound 4; then compounds 1 and 2 (each within the scatter of the next); then compound 3.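

In this assay, the first open chain at this place falls short of both bicyclic groups (a number 28 percentage points lower from compound 3 to compound 4 (beyond the scatter); a number 13 percentage points lower from compound 2 to compound 4 (beyond the scatter)). Before this result, the only measured change here was an exchange of one bicyclic group for another, so a ring-to-chain change had no measured direction; for this pair of changes, that direction is downward. No available evidence accounts for this loss.

A butyl chain, which has no ether oxygen, would test whether the loss follows the oxygen or the open chain. From the compounds shown here alone, whether a single ring such as cyclohexyl restores the read-out remains open.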